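The compounds below may be only part of what the source reports. "The series", "measured", "known", "first", "only" and "open" are said of these compounds alone.

Two compounds share one core and differ only in the group attached to the outer phenyl ring. Compound 1 `CC(C)(N)CC(=O)N[C@@H]1CCc2ccccc2N(Cc2ccc(-c3ccccc3C(=O)O)cc2)C1=O` carries a carboxy group there, and in a functional assay (Pituitary gland cell) with Rattus norvegicus as the target (a lower number here means that less compound is needed, a higher number that more compound is needed for the effect), compound 1 gives 2500 nM. Compound 2 `CC(C)(N)CC(=O)N[C@@H]1CCc2ccccc2N(Cc2ccc(-c3ccccc3-c3ncno3)cc2)C1=O` carries a 1,2,4-oxadiazol-5-yl group in its place, and in this assay compound 2 gives 30 nM. That single exchange produced an 83-fold lower number from compound 1 to compound 2 (1.92 log units; beyond the scatter). For the measured compounds named here, compound 2 thus stands as the lowest of the two numbers known so far, with compound 1 the only other point and far from it.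

Compound 3 `Cc1noc(-c2ccccc2-c2ccc(CN3C(=O)[C@H](NC(=O)CC(C)(C)N)CCc4ccccc43)cc2)n1` is the next compound, not yet measured. Its difference from compound 2 is methyl in place of hydrogen on an aromatic carbon. Going by the values given here, no measured step touches this kind of change: the one step on record, an 83-fold lower number from compound 1 to compound 2 (1.92 log units; beyond the scatter), swaps the whole carboxy group for the ring and says nothing about a methyl on an aromatic carbon of that five-membered aromatic ring. Lacking any comparable step, the expectation for compound 3 in this assay is no change at the digits printed from compound 2 to compound 3 (within the scatter), a step not beyond the scatter. Compound 3 is therefore estimated at 30 nM, with a range from 10 nM to 90 nM.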

Compound 3, half-maximal effective concentration: 1050 nM
Beside the measured number, compound 3's estimate is 35-fold (1.54 log units) below it, and the stated range ends below it.
By their numbers in this assay, from the lowest: compound 2; then compound 3; then compound 1.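

The new result shows that the aromatic carbon between two ring nitrogen atoms of the five-membered ring is a sensitive position in this assay: placing one methyl there, a single heavy atom, gives a 35-fold higher number from compound 2 to compound 3 (1.54 log units; beyond the scatter), a large step. Most of the earlier gain is lost, since the exchange of the carboxy group for the ring now gives only a 2.4-fold lower number from compound 1 to compound 3 (0.38 log units; beyond the scatter), a modest step though still beyond the scatter, against an 83-fold lower number from compound 1 to compound 2 (1.92 log units; beyond the scatter) for the ring without the methyl. Nothing on hand explains why so small an addition at this carbon counts for so much.

Going by these compounds, it remains open whether any other group on this carbon, such as a fluorine atom, an amine or a longer chain like ethyl, would give a number closer to that of compound 2 or to that of compound 1. On these data alone, it is also open whether the methyl step would keep its size on a core other than the shared one, since all three compounds carry the same core and only a single assay reads them.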